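This account rests on a few compounds, and the source may have more. Where it says the series, first, only, none or still open, it means among the compounds named here.

Compound 1 `N[C@H]1CC[C@H](CN(C[C@H]2Cc3ccccc3CN2)[C@H]2CCCc3cccnc32)CC1` is the reference. In an ADME assay on microsomes from liver (Rattus norvegicus) for metabolic stability (a higher number here means that more of the compound is left, a lower number that less of the compound is left), compound 1 gives 51%, the highest of the three numbers shown. Compound 2 `C/C(CN)=C(\F)CN(C[C@H]1Cc2ccccc2CN1)[C@H]1CCCc2cccnc21` gives 2% in this assay, and compound 3 `C/C(CN(C[C@H]1Cc2ccccc2CN1)[C@H]1CCCc2cccnc21)=C(\F)CN` gives 6% in this assay. The steps were a number 49 percentage points lower from compound 1 to compound 2 (beyond the scatter) and a number 45 percentage points lower from compound 1 to compound 3 (beyond the scatter), whereas between the two lower compounds it was a number 4 percentage points higher from compound 2 to compound 3 (within the scatter). Compound 4 `N[C@H]1CC[C@@H](N(C[C@H]2Cc3ccccc3CN2)[C@H]2CCCc3cccnc32)CC1` differs from compound 1 by 4-aminocyclohexyl in place of (4-aminocyclohexyl)methyl on an amine nitrogen. Within the data shown here, no measured step makes this kind of change; both large drops came from putting an entirely different group in place of 4-aminocyclohexyl, so they bear only loosely here. The expected step is therefore a number 6 percentage points lower from compound 1 to compound 4 (within the scatter), small and uncertain. Compound 4 is estimated at 45%, with a range from 20% to 70%.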

Compound 4, percent of the compound remaining: 24%
Compound 4: the middle estimate sits 21 percentage points above what was measured; low and high end bracket the measured number.
By their numbers in this assay, from the lowest: compounds 2 and 3 (each within the scatter of the next); then compound 4; then compound 1.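

Dropping the methyl link of (4-aminocyclohexyl)methyl on the amine nitrogen, while the aminocyclohexyl part stays, matters on its own in this assay: the result is a number 27 percentage points lower from compound 1 to compound 4 (beyond the scatter), so even this small shortening is not neutral here. The 4-aminocyclohexyl group still does better than the two open-chain groups on this nitrogen, with a number 18 percentage points higher from compound 3 to compound 4 (beyond the scatter) and a number 22 percentage points higher from compound 2 to compound 4 (beyond the scatter) in the same assay. Nothing measured here explains these steps.

From the compounds shown here alone, it remains open whether a longer chain, such as 2-(4-aminocyclohexyl)ethyl, would leave more of the compound than (4-aminocyclohexyl)methyl. Going by these compounds, it is also open how a hydroxyl group in place of the ring's amine would behave.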